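Lengthening the Chain on Compound 3

A few compounds are considered here, and "the series" means these few. Any claim that something is new, unique, unknown or untested is made for them only; others in the source may bear on it.

Three compounds have so far been tested in a functional assay on the whole organism (strain Holtzman) with Rattus norvegicus as the target; on this read-out higher numbers stand for an effect only at larger amounts of compound and lower numbers for an effect already at smaller amounts:

compound 1, `CCc1nn(C)c2c1C(c1ccccc1)=NCC(=O)N2`, 2.5 mg/kg
compound 2, `CCc1nn(C)c2c1C(c1ccc(F)cc1)=NCC(=O)N2`, > 40 mg/kg
compound 3, `CCc1nn(C)c2c1C(c1ccccc1Cl)=NCC(=O)N2`, 2.5 mg/kg

The value of compound 2 is a limit of this assay, not a number, as the sign before it shows. Compound 3 stands level with compound 1 at the digits shown, and the step of no change at the digits printed from compound 1 to compound 3 (within the scatter) lies within the scatter. The step of an at least 16-fold higher number from compound 1 to compound 2 (1.20 log units; beyond the scatter) and the step of an at least 16-fold lower number from compound 2 to compound 3 (1.20 log units; beyond the scatter), by contrast, are large, and the limit of > 40 mg/kg in this assay, at which 1 of the 3 values shown sits, marks where compound 2 sits.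

Compound 4, `CCCCc1nn(C)c2c1C(c1ccccc1Cl)=NCC(=O)N2`, differs from compound 3 in one place: ethyl in place of hydrogen on a saturated chain carbon, two bonds along the chain from an aromatic carbon. Among the measured compounds shown here, both measured steps concern the phenyl ring, not the chain, so no measured step bears directly on this change. For the measured compounds named here, the only guide is that compound 3 and compound 1 sit at the same value, and without a contrary signal the expected step of a 1.6-fold higher number from compound 3 to compound 4 (0.20 log units; within the scatter) is one that stays within the scatter. Compound 4 is therefore estimated at 4 mg/kg, with a range from 1.5 mg/kg to 12 mg/kg.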

Compound 4, minimum effective dose: > 40 mg/kg
Compound 4: only a limit was reported; the forecaster's own chance of this, stated with the estimate: 15%; middle value at least 10-fold (1.00 log units) away from the limit.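

Among the compounds shown here, the chain had not been touched in any earlier step, and the first change to it has a large effect in this assay: the step of an at least 16-fold higher number from compound 3 to compound 4 (1.20 log units; beyond the scatter) shows that this position does not accept the move from ethyl to butyl without loss. The change adds only 2 carbon atoms, with no ring and no net charge, so even a small extension here matters in this series. The value of compound 4 is a limit and not a number, and how far the compound lies past that limit cannot be told: the limit of > 40 mg/kg in this assay, at which 2 of the 4 values shown sit.

The compounds shown leave open where between ethyl and butyl the effect is lost, which a propyl chain would help to settle. They also leave open whether a branched isopropyl group, or a short chain ending in an amine or a carboxylic acid, would be accepted at this position.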